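The compounds below may be only part of what the source reports. "The series", "measured", "known", "first", "only" and "open" are said of these compounds alone.

Among the measured compounds shown here, compound 1 `COCCOc1nc(N)nc2c1ncn2/C=C1/CC1(CO)CO` is one of two compounds measured in an ADME assay on Akata cells (Homo sapiens) for cytotoxicity, with a stated time of 7 days; a lower number here means that less compound is tolerated, a higher number that more compound is tolerated. In this assay compound 1 gives > 20000 nM, which is a limit of the assay rather than a number. Compound 2 `CC(C)Sc1nc(N)nc2c1ncn2/C=C1/CC1(CO)CO`, with isopropylsulfanyl in place of 2-methoxyethoxy on an aromatic carbon, gives > 20000 nM, also a limit. The step that the two limits leave unreadable from compound 1 to compound 2 therefore cannot be read, since (the limit of > 20000 nM in this assay, at which 2 of the 2 values shown sit). Compound 3 `CCCOc1nc(N)nc2c1ncn2/C=C1/CC1(CO)CO` differs from compound 1 by methyl in place of methoxy on a saturated chain carbon, two bonds along the chain from an oxygen on an aromatic ring. For the measured compounds named here, only the step from compound 1 to compound 2 has been measured, and it shows no readable size, so the numbers give no guidance on direction. With both known compounds sitting at the limit, the expectation is that compound 3 also tolerates as much compound as the assay can report, so a step that the limit leaves unreadable from compound 1 to compound 3 is expected. Compound 3 is estimated at 30000 nM, within the range 15000 nM to 100000 nM.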

Compound 3, half-maximal cytotoxic concentration: > 20000 nM
Compound 3 was reported as a limit; the forecaster's own chance of this, stated with the estimate: 80%; the middle value is on the limit's open side.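

Compound 3 reads as a limit, as do compound 1 and compound 2, so no step among these three compounds can be read: (the limit of > 20000 nM in this assay, at which 3 of the 3 values shown sit). The compounds shown leave open whether these groups differ at all in how much compound the cells tolerate.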